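A few compounds are considered here, and "the series" means these few. Any claim that something is new, unique, unknown or untested is made for them only; others in the source may bear on it.

Within the data shown here, in a functional assay on HOP-62 cells (Homo sapiens) for inhibition, read by sulforhodamine B assay (on this read-out lower numbers stand for stronger inhibition of growth and higher numbers for weaker inhibition of growth), compound 1 (`c1ccc(-c2ccc(-c3ccc(-c4nc5ccccc5[nH]4)cc3)cc2)cc1`) gives 100000 nM, the highest number of the three measured so far. Compound 2 (`COc1ccc(-c2ccc(-c3ccc(-c4nc5cc(C)ccc5[nH]4)cc3)cc2)cc1OC`) gives 2120 nM and compound 3 (`COc1cc(-c2ccc(-c3ccc(-c4nc5cc(C)ccc5[nH]4)cc3)cc2)cc(OC)c1OC`) gives 2370 nM, and both lie beyond the scatter from compound 1. Compound 4 (`FC(F)(F)c1ccc(-c2ccc(-c3ccc(-c4nc5ccccc5[nH]4)cc3)cc2)cc1`) departs from compound 1 in one place: trifluoromethyl in place of hydrogen on an aromatic carbon, with trifluoromethyl in place of hydrogen on an aromatic carbon, para to a large group.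

Among the measured compounds shown here, no measured step shows this change. For the measured compounds named here, the only single-place step, a 1.1-fold higher number from compound 2 to compound 3 (0.05 log units; within the scatter), is methoxy in place of hydrogen on an aromatic carbon, and it stays within the scatter. Compound 2 and compound 3 each differ from compound 1 in more than one place, so their lower numbers cannot be credited to any one group. Even so, the gap between compound 1 at 100000 nM and compound 2 at 2120 nM leaves room for a fall, while compound 1 offers little room for a rise. A moderate move towards a lower number is therefore expected, with wide uncertainty. The expected change is a 5.0-fold lower number from compound 1 to compound 4 (0.70 log units; beyond the scatter). Compound 4 is estimated at 20000 nM, with an expected range from 3000 nM to 100000 nM.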

Compound 4, concentration for 50% growth inhibition: 100000 nM
For compound 4 the middle estimate is 5.0-fold (0.70 log units) below the measured one, and the stated range covers the measured number.
By their numbers in this assay, from the lowest: compounds 2 and 3 (each within the scatter of the next); then compounds 1 and 4 (each within the scatter of the next).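

In this assay, among these compounds, the step from phenyl to 4-(trifluoromethyl)phenyl gives no change at the digits printed from compound 1 to compound 4 (within the scatter), the first direct reading of a change on this aromatic carbon, para to a large group. Among the compounds shown here, the only earlier step was a methoxy change between two compounds that both differ from compound 1 in more than one place, so it said nothing about this position on the core of compound 1. Here, trifluoromethyl in place of hydrogen does not separate compound 4 from compound 1, and no measurement at hand offers an explanation for this result.

The compounds shown leave open whether a different group at this same place, such as an amine or a carboxylic acid, would also give no change from compound 1. They also leave unresolved which of the differences between compound 1 and compounds 2 and 3 accounts for the lower numbers of those two compounds, since no single-place step connects either of them to compound 1.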